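The compounds below may be only part of what the source reports. "The series", "measured", "known", "first", "only" and "open" are said of these compounds alone.

In a functional assay on KYSE-450 cells (Homo sapiens) for inhibition, read by CCK-8 assay, with a stated time of 48 h (a lower number here means a stronger inhibitor, a higher number a weaker inhibitor), compound 3 (`COc1cc(N(Cc2ccc(Cl)cc2)C(=O)CSC(=S)N2CCN(C(=O)OC(C)(C)C)CC2)cc(OC)c1OC`) gives 11900 nM and is the weakest of the three measured compounds, with compound 1 (`COc1ccc(CN(C(=O)CSc2nc3ccccc3o2)c2cc(OC)c(OC)c(OC)c2)cc1`) at 840 nM and compound 2 (`COc1ccc(CN(C(=O)CSC(=S)N2CCN(C)CC2)c2cc(OC)c(OC)c(OC)c2)cc1`) at 1250 nM on the stronger side. Compound 4 (`COc1ccc(CN(C(=O)CSC(=S)N2CCN(C(=O)OC(C)(C)C)CC2)c2cc(OC)c(OC)c(OC)c2)cc1OC`) differs from compound 3 in one place: 3,4-dimethoxyphenyl in place of 4-chlorophenyl on a saturated chain carbon bound to an amide-type nitrogen (4-chlorobenzyl to 3,4-dimethoxybenzyl). For the measured compounds named here, no measured step changes this benzyl group. Going by the values given here, the only step available (a 1.5-fold higher number from compound 1 to compound 2 (0.17 log units; within the scatter)) swaps the group on a sulfur instead and stays within the scatter, so it offers little guidance. A modest fall is expected, on the weak ground that compound 3 at 11900 nM sits at the top of the set. The expected change is a 2.4-fold lower number from compound 3 to compound 4 (0.38 log units; beyond the scatter) and it remains loosely known. For compound 4 the estimated value is 5000 nM with an expected range of 1500 nM to 16000 nM in this assay.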

Compound 4, half-maximal inhibitory concentration: > 20000 nM
Compound 4 gave a limit, no number; the forecaster's own chance of this, stated with the estimate: 3%; at least 4.0-fold (0.60 log units) between middle value and limit.
By their numbers in this assay, from the lowest: compounds 1 and 2 (each within the scatter of the next); then compound 3. At a limit, above all of these: compound 4.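

For the compounds shown here, the benzyl group on the amide-type nitrogen changes here for the first time in this assay, so this is the first reading of that place. Compound 4 stands at a limit of the assay, not at a number: the limit of > 20000 nM in this assay, at which 1 of the 4 values shown sits. On these data alone, the step reads an at least 1.6-fold higher number from compound 3 to compound 4 (0.22 log units; that floor lies within the scatter), so 3,4-dimethoxybenzyl shows no gain over 4-chlorobenzyl, while the true size of the change stays unknown.

The compounds shown leave open how a plain benzyl or a 4-fluorobenzyl group would read on this same core. They also leave open whether 3,4-dimethoxybenzyl would read the same on the core of compound 2.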